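Trimming the Isopropyl From a Fused Oxazole Core

This account rests on a few compounds, and the source may have more. Where it says the series, first, only, none or still open, it means among the compounds named here.

Three compounds have been measured in an assay on HEK293 cells for binding affinity to Neuronal acetylcholine receptor; alpha4/beta2 (Homo sapiens); on this read-out lower numbers stand for stronger inhibition and higher numbers for weaker inhibition:

- compound 1, `CC(C)c1nc2cc3c(cc2o1)C1CNCC3C1`, gives 1.9 nM
- compound 2, `Oc1cccc2c1C1CNCC2C1`, gives 1700 nM
- compound 3, `Cc1nc2cc3c(cc2nc1C)C1CNCC3C1`, gives 0.55 nM

Among these three numbers compound 1 holds the second highest. Its nearest neighbour is compound 3, whose number is lower by a margin that lies beyond the usual scatter of this assay. Its most distant neighbour is compound 2, whose number is far higher, again well beyond the scatter. So compound 1 sits closer to the strong end of the range than to the weak end.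

The new compound, compound 4, `c1nc2cc3c(cc2o1)C1CNCC3C1`, keeps the whole core of compound 1 and differs from it in one place: hydrogen in place of isopropyl on an aromatic carbon. Going by the values given here, no pair of measured compounds shows this exact change, so there is no measured step to lean on. The three measured values show that the fused heteroaromatic ring carries much of the affinity, while the substituent on that ring has not been varied.

On this basis the step from compound 1 to compound 4 is expected to be small, most likely within the scatter, a 1.3-fold lower number from compound 1 to compound 4 (0.10 log units; within the scatter). Compound 4 is therefore estimated at 1.5 nM, with a range from 0.4 nM to 6 nM.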

Compound 4, inhibition constant: 0.16 nM
Compound 4: the middle estimate sits 9.4-fold (0.97 log units) above what was measured, outside the stated range (below it).
By their numbers in this assay, from the lowest: compound 4; then compound 3; then compound 1; then compound 2.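

In this assay, replacing the isopropyl on the aromatic carbon of the five-membered ring with a bare hydrogen gives a 12-fold lower number from compound 1 to compound 4 (1.07 log units; beyond the scatter) and shows that this position is sensitive to what it carries. Going by these compounds alone, the earlier compounds offered no change at this place, so only this step reveals that the isopropyl is not needed for binding here and that compound 4, with hydrogen alone, binds more tightly than compound 1. Nothing measured here explains why removing these three carbons has so large an effect, so the step records the size of the change but not its cause.

The compounds shown leave open whether the number rises gradually with chain length, which a methyl or an ethyl on the same carbon would help to settle. They also leave open how groups of a different kind, such as an amine or a methoxy group, would behave at this position, and whether removing the isopropyl would have the same effect on a different core.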